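Swapping a Phenoxy for a Spirocyclic Amine: Solubility Outlook

This account rests on a few compounds, and the source may have more. Where it says the series, first, only, none or still open, it means among the compounds named here.

Compound 1 `COc1ccc2[nH]c(C(=O)N3CC(=O)N(Cc4ccccc4)[C@@H](COc4ccccc4)C3)cc2c1` — 12200 nM
Compound 2 `COc1ccc2[nH]c(C(=O)N3CC(=O)N(Cc4ccccc4)[C@@H](CN4CCN(S(=O)(=O)c5ccccc5)CC4)C3)cc2c1` — 16900 nM
Compound 3 `COc1cccc(CN2C(=O)CN(C(=O)c3cc4cc(OC)ccc4[nH]3)C[C@@H]2c2ccccc2)c1` — 13600 nM

All three values were read in a physicochemical assay for solubility, read by spectrophotometry, in phosphate buffer, with a stated time of 2 h, at pH 7.4; on this read-out higher numbers stand for higher solubility and lower numbers for lower solubility. Compound 1 holds the lowest of the three numbers, yet its distances to compound 3 and to compound 2 both fall within the usual scatter, so the three compounds cannot be told apart on these readings. Compound 4 `COc1ccc2[nH]c(C(=O)N3CC(=O)N(Cc4ccccc4)[C@@H](CN4CC5(CCC5)C4)C3)cc2c1` differs from compound 1 at a single place: a group of 7 heavy atoms (6 carbon, 1 nitrogen; one four-membered non-aromatic ring of carbon only, one four-membered non-aromatic ring with 1 hetero atom) in place of a group of 7 heavy atoms (6 carbon, 1 oxygen; one six-membered aromatic ring of carbon only), on a saturated chain carbon bound to a saturated ring carbon. For the measured compounds named here, no measured pair shows a change of this kind, so the size of the step rests on judgment alone. The step from compound 1 to compound 4 is expected to be a 2.5-fold higher number from compound 1 to compound 4 (0.39 log units; beyond the scatter), pointing toward higher solubility and modestly beyond the scatter. Compound 4 is therefore expected to give 30000 nM, within a range from 10000 nM to 90000 nM.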

Compound 4, solubility: 60700 nM
The estimate for compound 4 lay 2.0-fold (0.31 log units) below the measured number, within the range that was stated.
By their numbers in this assay, from the lowest: compounds 1, 3 and 2 (each within the scatter of the next); then compound 4.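

Replacing the phenoxy on the saturated chain carbon with the group bearing two four-membered rings gives a 5.0-fold higher number from compound 1 to compound 4 (0.70 log units; beyond the scatter) in this assay. Compounds 1, 2 and 3 could not be told apart, whereas this change moves the number beyond the scatter, even though the groups that leave and enter match in heavy-atom, donor and acceptor counts. Nothing measured here explains this step.

From the compounds shown here alone, whether the ring nitrogen or the loss of the aromatic ring matters more remains open. A cyclohexyl group or a dimethylamino group at the same place would help separate the two.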